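This account rests on a few compounds, and the source may have more. Where it says the series, first, only, none or still open, it means among the compounds named here.

Compound 1 `Cc1cccc(Cn2cc(COc3ccc4c(=O)ccoc4c3)nn2)c1`: 22400 nM
Compound 2 `Cc1ccc(Cn2cc(COc3ccc4c(=O)ccoc4c3)nn2)cc1`: 68500 nM
Compound 3 `O=c1ccoc2cc(OCc3cn(Cc4ccc(Cl)cc4)nn3)ccc12`: 41700 nM

All three values come from a functional assay on QGY7701 cells (Homo sapiens) for cytotoxicity, read by MTT assay, with a stated time of 48 h; on this read-out higher numbers stand for weaker inhibition and lower numbers for stronger inhibition. Compound 3 sits close to both of the others, as the steps show: a 1.9-fold higher number from compound 1 to compound 3 (0.27 log units; within the scatter), and a 1.6-fold lower number from compound 2 to compound 3 (0.22 log units; within the scatter). Neither step separates it from its neighbour.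

Compound 4 `O=c1ccoc2cc(OCc3cn(Cc4ccc(Br)cc4)nn3)ccc12` has not been measured yet. It differs from compound 3 in one place: bromo in place of chloro on an aromatic carbon. In plain terms, this is bromo in place of chloro on an aromatic carbon, turning 4-chlorobenzyl into 4-bromobenzyl.

Among the compounds with values here, no measured pair makes this exact exchange, so the evidence is indirect. Within the data shown here, the nearest precedent is a swap of one group for another on an aromatic carbon, chloro in place of methyl, and it gave a 1.6-fold lower number from compound 2 to compound 3 (0.22 log units; within the scatter). Among the measured compounds shown here, the only step beyond the scatter is a 3.1-fold higher number from compound 1 to compound 2 (0.49 log units; beyond the scatter), a modest one, and it moves the methyl group around the ring, which the present change does not do.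

No step beyond the scatter is therefore expected in this assay. The estimated step is a 1.0-fold higher number from compound 3 to compound 4 (0.00 log units; within the scatter). For compound 4 the expected value is 42000 nM, with an estimated range from 20000 nM to 85000 nM.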

Compound 4, half-maximal inhibitory concentration: 96400 nM
For compound 4 the middle estimate is 2.3-fold (0.36 log units) below the measured one, and the stated range ends below it.
By their numbers in this assay, from the lowest: compounds 1, 3, 2 and 4 (each within the scatter of the next, the first and the last beyond it).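

In this assay, the para-substituent on this ring is not interchangeable among halogens: swapping one heavy atom for another, with no donor or acceptor gained or lost, gives a 2.3-fold higher number from compound 3 to compound 4 (0.36 log units; beyond the scatter), a modest but real loss of inhibition. Bromo and methyl at this same carbon cannot be told apart, with a 1.4-fold higher number from compound 2 to compound 4 (0.15 log units; within the scatter), whereas the exchange of 3-methylphenyl for 4-bromophenyl, which changes both the group and where it sits on the ring, gives a 4.3-fold higher number from compound 1 to compound 4 (0.63 log units; beyond the scatter), again modest and towards weaker inhibition. The data offer no measured property that accounts for the difference between chloro and bromo.

Going by these compounds, what a fluoro, a methoxy or an amine on this aromatic carbon would do remains open, so these four compounds cannot show whether the read-out follows any simple trend across groups at this place. On these data alone, it is also open whether the step between 4-chlorobenzyl and 4-bromobenzyl would appear in a different cell line or would carry over to a longer chain between the ring and the aromatic nitrogen.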